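This account rests on a few compounds, and the source may have more. Where it says the series, first, only, none or still open, it means among the compounds named here.

In a functional assay on K562 cells (Homo sapiens), read by MTT assay, with a stated time of 72 h (on this read-out lower numbers stand for stronger inhibition and higher numbers for weaker inhibition), three compounds have been measured so far. Compound 1 `C#Cc1cn([C@@H]2O[C@H](CO)[C@@H](O)[C@H]2O)c2ncnc(OC)c12` gives 380 nM, compound 2 `C#Cc1cn([C@@H]2O[C@H](CO)[C@@H](O)[C@H]2O)c2ncnc(SC)c12` gives 70 nM, and compound 3 `Cc1ncnc2c1c(-c1ccsc1)cn2[C@@H]1O[C@H](CO)[C@@H](O)[C@H]1O` gives 5550 nM. This last value is the highest of the three and lies beyond the scatter from both of the others. Compound 4 `C#Cc1cn([C@@H]2O[C@H](CO)[C@@H](O)[C@H]2O)c2ncnc(C)c12` differs from compound 3 in one place: ethynyl in place of thiophen-3-yl on an aromatic carbon. This puts ethynyl in place of thiophen-3-yl on an aromatic carbon.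

For the measured compounds named here, no measured step covers this exchange directly. The closest evidence is that compound 1 and compound 2 both carry ethynyl, and both have much lower numbers than compound 3. Going by the values given here, the one measured step, a 5.4-fold lower number from compound 1 to compound 2 (0.73 log units; beyond the scatter), is methylsulfanyl in place of methoxy on an aromatic carbon, a modest change. Compound 4 carries neither of those two groups, so its value remains uncertain. A large downward step is nevertheless expected, a 37-fold lower number from compound 3 to compound 4 (1.57 log units; beyond the scatter). Compound 4 is estimated at 150 nM, within an expected range of 30 nM to 800 nM.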

Compound 4, half-maximal inhibitory concentration: 110 nM
Compound 4: middle estimate off by 1.4-fold (0.13 log units), on the high side; the measured number falls inside the stated range.
By their numbers in this assay, from the lowest: compounds 2 and 4 (each within the scatter of the next); then compound 1; then compound 3.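

In this assay the exchange on the aromatic carbon of the five-membered ring gives a 50-fold lower number from compound 3 to compound 4 (1.70 log units; beyond the scatter) and is a large step, the first one measured at this position. With ethynyl held constant, methyl and methylsulfanyl lie within the scatter of each other, at a 1.6-fold higher number from compound 2 to compound 4 (0.20 log units; within the scatter) in this comparison, whereas methyl and methoxy lie beyond it, at a 3.5-fold lower number from compound 1 to compound 4 (0.54 log units; beyond the scatter) in theirs. Nothing available explains these differences.

The compounds shown leave open how other groups at the ethynyl position, such as a nitrile, a phenyl ring or a longer chain, would read. Thiophen-3-yl also appears only alongside methyl, so it remains open whether the large step would hold with methoxy, methylsulfanyl or an amine in place of that methyl.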